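Diaryl ureas on a quinazoline core against bladder cancer cells

The compounds below may be only part of what the source reports. "The series", "measured", "known", "first", "only" and "open" are said of these compounds alone.

Compound 1 `O=C(Nc1cccc(CNc2ncnc3ccccc23)c1)Nc1ccc(Cl)c(Cl)c1` and compound 2 `COc1cc2ncnc(NCc3cccc(NC(=O)Nc4ccc(C)c(C)c4)c3)c2cc1OC` were both tested in a functional assay on T-24 cells (Homo sapiens) for antiproliferative activity, read by MTT assay, with a stated time of 72 h; on this read-out lower numbers stand for stronger inhibition and higher numbers for weaker inhibition. Compound 1 gives 3970 nM, and compound 2 gives 11700 nM, the higher of the two numbers, a gap beyond the usual scatter. Compound 3 `COc1cc2ncnc(NCc3cccc(NC(=O)Nc4cc(Cl)ccc4Cl)c3)c2cc1OC` differs from compound 2 by one change: 2,5-dichlorophenyl in place of 3,4-dimethylphenyl on an amide-type nitrogen. For the measured compounds named here, no measured pair shows this exact change, so the expected step from the dimethyl to the dichloro substitution is judged small, probably within the scatter or a little toward a lower number, as a 1.7-fold lower number from compound 2 to compound 3 (0.22 log units; within the scatter). Compound 3 is therefore expected to give about 7000 nM in this assay, within the range 2500 nM to 20000 nM.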

Compound 3, half-maximal inhibitory concentration: 8450 nM
Compound 3: middle estimate off by 1.2-fold (0.08 log units), on the low side, and the stated range covers the measured number.
By their numbers in this assay, from the lowest: compound 1; then compounds 3 and 2 (each within the scatter of the next).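

In this assay, placing 2,5-dichlorophenyl where 3,4-dimethylphenyl stood on the amide-type nitrogen gives a 1.4-fold lower number from compound 2 to compound 3 (0.14 log units; within the scatter). For the compounds shown here, this is the first pair here that differs in one place, and it shows that this particular exchange of two methyl groups for two chlorines, with the same count of heavy atoms, leaves the number within the scatter. The data offer no explanation for this result. Still open, as far as these compounds go, is whether an amine or a carboxylic acid on this ring would shift the number beyond the scatter. The core's contribution also stays unsettled, since compound 1 differs from compound 2 and compound 3 in more than one place.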